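Methoxy for Chloro on the Core of Compound 3

A few compounds are considered here, and "the series" means these few. Any claim that something is new, unique, unknown or untested is made for them only; others in the source may bear on it.

Of the three measured compounds, compound 3 `C[C@@H]1CN(c2ncccc2Cl)CCN1c1nc2cc(Cl)ccc2[nH]1` stands highest in a functional assay on HEK293 cells for antagonist activity at transient receptor potential cation channel subfamily V member 1 (Homo sapiens), read by FLIPR (a lower number here means a stronger inhibitor, a higher number a weaker inhibitor), where compound 3 gives 325 nM. Compound 1 `CC(C)(C)c1ccc2[nH]c(N3CCN(c4ncccc4Cl)CC3)nc2c1` gives 136 nM and compound 2 `C[C@@H]1CN(c2ncccc2Cl)CCN1c1nc2ccc(C(C)(C)C)cc2[nH]1` gives 90.4 nM in this assay, so compound 3 is the weakest of the three, both gaps lying beyond the scatter. Compound 4 `COc1ccc2[nH]c(N3CCN(c4ncccc4Cl)C[C@H]3C)nc2c1` has not yet been measured. It differs from compound 3 in one place: methoxy in place of chloro on an aromatic carbon. Among the compounds with values here, no pair of measured compounds differs in this way, so this step has no precedent among them. The change is expected to move the number little, with a 1.3-fold higher number from compound 3 to compound 4 (0.11 log units; within the scatter) estimated as a slight rise that may not exceed the scatter. Compound 4 is therefore expected to give about 420 nM in this assay, within a range from 150 nM to 1200 nM.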

Compound 4, half-maximal inhibitory concentration: 665 nM
For compound 4 the middle estimate is 1.6-fold (0.20 log units) below the measured one, within the range that was stated.
By their numbers in this assay, from the lowest: compounds 2 and 1 (each within the scatter of the next); then compound 3; then compound 4.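

In this assay, methoxy in place of chloro on this aromatic carbon gives a 2.0-fold higher number from compound 3 to compound 4 (0.31 log units; beyond the scatter), a modest loss of inhibition that lies beyond the scatter. This first one-place step among these compounds shows that the number at this position responds to the group placed there, and that chloro gives the stronger inhibitor of this pair. Nothing measured here accounts for the step. As far as these compounds go, whether fluoro, an amine or a longer alkoxy chain on this carbon would give a lower or higher number stays open. So does whether the same change would give a similar step on another compound.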